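A few compounds are considered here, and "the series" means these few. Any claim that something is new, unique, unknown or untested is made for them only; others in the source may bear on it.

Compound 1 `O=C(/C(=C\c1ccc(I)cc1)S(=O)(=O)c1ccc(Br)cc1)c1ccc(Br)cc1` is examined in a functional assay on DU-145 cells (Homo sapiens) for inhibition, read by trypan blue exclusion, with a stated time of 96 h; on this read-out lower numbers stand for stronger inhibition of growth and higher numbers for weaker inhibition of growth. In this assay compound 1 gives 1000 nM. For the measured compounds named here, the only other measured compound, compound 2 `O=C(/C(=C\c1c(O)cc(O)cc1O)SCc1ccc(Cl)c(Cl)c1)c1ccc(Cl)cc1`, has a different core and gives 25000 nM in this assay, so compound 1 holds the lowest of the two numbers, and the gap to compound 2 lies beyond the usual scatter. Going by the values given here, no step between two measured compounds that differ in one place is available, so compound 2 can only be read as a distant comparison.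

Compound 3 `COc1cccc(OC)c1/C=C(\C(=O)c1ccc(Br)cc1)S(=O)(=O)c1ccc(Br)cc1` has not yet been measured in this assay. It differs from compound 1 in one place: 2,6-dimethoxyphenyl in place of 4-iodophenyl on a double-bonded chain carbon bound to a double-bonded chain carbon. Among the compounds with values here, nothing among the measured compounds shows how this exchange on the shared core of compound 1 acts on growth inhibition of these cells. The expectation is therefore cautious: a step of modest size, if any, and more likely toward a higher number than toward a lower one, so the step from a 2.0-fold higher number from compound 1 to compound 3 (0.30 log units; within the scatter) is an estimate rather than a prediction resting on an observed trend. Compound 3 is accordingly expected to give about 2000 nM, within a range from 500 nM to 8000 nM, in this assay.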

Compound 3, concentration for 50% growth inhibition: 10000 nM
Compound 3: the middle estimate sits 5.0-fold (0.70 log units) below what was measured; measured number outside the range, above it.
By their numbers in this assay, from the lowest: compound 1; then compound 3; then compound 2.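

For the compounds shown here, the exchange of 4-iodophenyl for 2,6-dimethoxyphenyl on a double-bonded chain carbon bound to a double-bonded chain carbon gives the first direct reading of this position on the shared core: in this assay it brings a 10-fold higher number from compound 1 to compound 3 (1.00 log units; beyond the scatter) and so weakens growth inhibition of these cells. The position is therefore not indifferent to what the aromatic ring carries, even though both compounds keep one six-membered aromatic ring of carbon only there, and of the two groups seen at this place 4-iodophenyl gives the stronger inhibition. Nothing available accounts for this loss, and on this single pair the added oxygen atoms, the loss of iodine and the rise in heavy atoms cannot be told apart.

The compounds shown leave open whether the loss follows from gaining the two methoxy groups or from losing the iodine, a question that a plain phenyl ring or a ring carrying a single methoxy group at this place would address. They also leave open how a ring bearing an amine or a carboxylic acid at this position would act on growth inhibition in this assay on the same core.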